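Moving from pyridin-4-yl to 4-methylphenyl on the thiophene

The source may hold more compounds than are shown below. What is called first, only, known or untested is meant among the compounds shown, and "the series" means these compounds.

Measured so far:
compound 1, `Cc1sc(N)c(C(=O)c2ccc(Cl)cc2)c1-c1ccccc1`, 1%
compound 2, `Nc1sc(-c2ccccc2)c(-c2ccccc2)c1C(=O)c1ccc(Cl)cc1`, 1%
compound 3, `CC(C)(C)Cc1c(-c2ccncc2)sc(N)c1C(=O)c1ccc(Cl)cc1`, 1%

In an assay on CHO cells for displacement of a labelled ligand from adenosine receptor A1 (Homo sapiens), read by scintillation counting, tested at 10 uM (a lower number here means less inhibition, a higher number more inhibition at the concentration tested (going by the name of the read-out)), compound 1 gives 1%, and compound 2 gives 1%. Within the data shown here, the one measured step, no change at the digits printed from compound 1 to compound 2 (within the scatter), shows that enlarging the group on the shared core from methyl to phenyl leaves the read-out where it was. Compound 3, which carries a neopentyl group and a pyridin-4-yl group on the core, gives 1% and so stands level with compounds 1 and 2 within the scatter.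

Compound 4, `Cc1ccc(-c2sc(N)c(C(=O)c3ccc(Cl)cc3)c2CC(C)(C)C)cc1`, is not yet measured. Its difference from compound 3 is 4-methylphenyl in place of pyridin-4-yl on an aromatic carbon. Among the measured compounds shown here, no measured step touches this exact position, but the step from a methyl to a phenyl elsewhere on the core was flat, and every measured value sits at the floor of this assay. The expected step of a number 1 percentage points higher from compound 3 to compound 4 (within the scatter) is therefore none beyond the scatter. Compound 4 is expected to give about 2% in this assay, in the range -8% to 15%.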

Compound 4, a percentage reported as inhibition, at one concentration (the size of the read-out at that concentration, not a potency): 1%
Beside the measured number, compound 4's estimate is 1 percentage points above it; measured number inside the range.
By their numbers in this assay, from the lowest: compounds 1, 2, 3 and 4 (each within the scatter of the next).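

In this assay, 4-methylphenyl in place of pyridin-4-yl, on the aromatic carbon next to the ring sulfur, gives no change at the digits printed from compound 3 to compound 4 (within the scatter). The earlier step exchanged methyl for phenyl, whereas this one exchanges one six-membered aromatic ring for another, with the ring nitrogen and its hydrogen-bond acceptor gone and the neopentyl group held in place. Here, then, a ring of carbon only and a ring with a hetero atom cannot be told apart by this read-out.

All four compounds stand level, so the series does not show which change on the shared core, if any, would move the read-out. On these data alone, whether an amine or a carboxylic acid on this aromatic ring, or a longer chain in place of the neopentyl group, would do so remains open. Nothing available explains why this exchange leaves the read-out unmoved.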